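The source may hold more compounds than are shown below. What is called first, only, known or untested is meant among the compounds shown, and "the series" means these compounds.

Working notes on the series. All three measured members share the core of compound 1 `CC(=O)Nc1ccc(S(=O)(=O)Oc2ccccc2C(C)C)cc1` and differ only in the group on the carbonyl carbon of the anilide. In a functional assay on HT-29 cells (Homo sapiens) for antiproliferative activity, read by sulforhodamine B assay, with a stated time of 48 h (on this read-out lower numbers stand for stronger inhibition and higher numbers for weaker inhibition), compound 1 gives 23000 nM. Compound 2 `CC(C)C(=O)Nc1ccc(S(=O)(=O)Oc2ccccc2C(C)C)cc1` gives 14000 nM in this assay, and the step of a 1.6-fold lower number from compound 1 to compound 2 (0.22 log units; within the scatter). Compound 3 `CC(C)c1ccccc1OS(=O)(=O)c1ccc(NC(=O)CCCCl)cc1` gives 6200 nM in this assay, the lowest of the three numbers; a 3.7-fold lower number from compound 1 to compound 3 (0.57 log units; beyond the scatter), and a 2.3-fold lower number from compound 2 to compound 3 (0.35 log units; beyond the scatter).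

Compound 4 `CC(C)c1ccccc1OS(=O)(=O)c1ccc(NC(=O)NCC2CCCC2)cc1` is not yet measured. It differs from compound 3 by (cyclopentylmethyl)amino in place of 3-chloropropyl on a carbonyl carbon. Among the compounds with values here, no measured step exchanges an acyl group for a carbamoyl group, so the three steps bear on it only loosely: they show that varying the group on this carbonyl carbon has moved the numbers in this assay by modest amounts at most, with a 1.6-fold lower number from compound 1 to compound 2 (0.22 log units; within the scatter) within the scatter and the two steps into compound 3 modest. A modest step back toward the numbers of compound 1 and compound 2 is therefore expected rather than a large one; in this assay the expected step is a 1.5-fold higher number from compound 3 to compound 4 (0.16 log units; within the scatter). Compound 4 is estimated at 9000 nM, with a range of 3000 nM to 27000 nM.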

Compound 4, half-maximal inhibitory concentration: 6800 nM
Compound 4: middle estimate off by 1.3-fold (0.12 log units), on the high side; low and high end bracket the measured number.
By their numbers in this assay, from the lowest: compounds 3 and 4 (each within the scatter of the next); then compounds 2 and 1 (each within the scatter of the next).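

In this assay, the carbonyl carbon takes a carbamoyl group as well as an acyl group: with (cyclopentylmethyl)amino in place of 3-chloropropyl there is a 1.1-fold higher number from compound 3 to compound 4 (0.04 log units; within the scatter) and no separation between the two compounds, so among these compounds the chlorine is not needed to reach this level. The same group, set against the smaller acyl substituents, gives a 2.1-fold lower number from compound 2 to compound 4 (0.31 log units; beyond the scatter) and a 3.4-fold lower number from compound 1 to compound 4 (0.53 log units; beyond the scatter), which places compound 4 with compound 3 and apart from compound 1 and compound 2. Nothing available accounts for this equivalence or says whether the two compounds act in the same way.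

The nitrogen, the ring and the loss of chlorine all change together in this step, so their separate contributions remain unresolved. A (3-chloropropyl)amino group or a plain butyl group on the same carbonyl carbon would bear on that, and a terminal amine or carboxylic acid on the chain remains an open variation.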